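Aryl replacement on the shared core: expectation for compound 3

The source may hold more compounds than are shown below. What is called first, only, known or untested is meant among the compounds shown, and "the series" means these compounds.

compound 1 `CC(C(=O)NCc1ccc(C(F)(F)F)nc1-c1ccccc1)c1ccc(NS(C)(=O)=O)c(F)c1` — 6.4 nM
compound 2 `Cc1cc(-c2nc(C(F)(F)F)ccc2CNC(=O)C(C)c2ccc(NS(C)(=O)=O)c(F)c2)ccc1F` — 0.4 nM

In an assay on CHO cells for antagonist activity at transient receptor potential cation channel subfamily V member 1 (Homo sapiens), read by FLIPR (a higher number here means a weaker inhibitor, a lower number a stronger inhibitor), compound 1 gives 6.4 nM and compound 2 gives 0.4 nM. Among the compounds with values here, compound 2 holds the lowest of the two numbers; the one measured step, a 16-fold lower number from compound 1 to compound 2 (1.20 log units; beyond the scatter), is large and beyond the scatter. Compound 3 `CC(C(=O)NCc1ccc(C(F)(F)F)nc1-c1ccsc1)c1ccc(NS(C)(=O)=O)c(F)c1` is not yet measured; it differs from compound 2 by thiophen-3-yl in place of 4-fluoro-3-methylphenyl on an aromatic carbon. Within the data shown here, that step touches the same position as the measured one, so the group that set compound 2 apart from compound 1 is removed, and thiophen-3-yl has no measured precedent here. A step back toward the number of compound 1 is therefore expected, a 20-fold higher number from compound 2 to compound 3 (1.30 log units; beyond the scatter). For compound 3 the estimate is 8 nM, with a range of 2 nM to 30 nM.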

Compound 3, inhibition constant: 2 nM
Estimate against measurement, compound 3: 4.0-fold (0.60 log units) above; the measured number falls inside the stated range.
By their numbers in this assay, from the lowest: compound 2; then compound 3; then compound 1.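

On the aromatic carbon next to the ring nitrogen, in this assay, thiophen-3-yl gives a 3.2-fold lower number from compound 1 to compound 3 (0.51 log units; beyond the scatter), so a lower number than with phenyl is not confined to 4-fluoro-3-methylphenyl and also occurs with a five-membered aromatic ring holding sulfur. The thiophene does not match the substituted phenyl, with a 5.0-fold higher number from compound 2 to compound 3 (0.70 log units; beyond the scatter), leaving 4-fluoro-3-methylphenyl lowest of the three. Nothing available explains either step.

Open, as far as these compounds go, is whether fluorine or methyl alone accounts for the lower number of compound 2. Also open, from the compounds shown here alone, is how a non-aromatic group at this position, such as an amine, would compare.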